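Methoxy to ethyl: from compound 3 to compound 4

The source may report more compounds than this note shows. Statements on the series, on what has been measured and on what is new or still open speak of the compounds shown alone.

Compound 3 `COc1ncc(-c2nc(C(F)(F)F)sc2N2CCN(C(=O)Cn3nc(C)nc3C)[C@H](C)C2)cn1` gives 1040 nM in an assay on blood for inhibition of C-X-C chemokine receptor type 3 (Homo sapiens), with a stated time of 30 min (on this read-out higher numbers stand for weaker inhibition and lower numbers for stronger inhibition), the highest number among the three measured compounds. Compound 1 `COc1ncc(-c2nc(C(F)(F)F)sc2N2CCN(C(=O)Cn3cnc4cccnc43)[C@H](C)C2)cn1` gives 158 nM in this assay, and compound 2 `CCOc1ncc(-c2nc(C(F)(F)F)sc2N2CCN(C(=O)Cn3cc(Cl)cn3)[C@H](C)C2)cn1` gives 245 nM. For the measured compounds named here, the one single-site step known here is a 6.6-fold higher number from compound 1 to compound 3 (0.82 log units; beyond the scatter), a change of the amide-linked heteroaryl group rather than of the ether side.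

Compound 4 `CCc1ncc(-c2nc(C(F)(F)F)sc2N2CCN(C(=O)Cn3nc(C)nc3C)[C@H](C)C2)cn1` differs from compound 3 by ethyl in place of methoxy on an aromatic carbon. Going by the values given here, no measured step touches this position: compound 1 and compound 2 differ in two places at once, so their values show only that both lie well under compound 3. With nothing bearing on the change, compound 4 is expected to show a 1.1-fold higher number from compound 3 to compound 4 (0.02 log units; within the scatter), a step not beyond the scatter. Compound 4 is therefore estimated at 1100 nM, with a range from 450 nM to 2800 nM.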

Compound 4, half-maximal inhibitory concentration: 567 nM
Compound 4: the middle estimate sits 1.9-fold (0.29 log units) above what was measured; low and high end bracket the measured number.
By their numbers in this assay, from the lowest: compounds 1 and 2 (each within the scatter of the next); then compounds 4 and 3 (each within the scatter of the next).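

For the compounds shown here, the first single-site step at this position, a 1.8-fold lower number from compound 3 to compound 4 (0.26 log units; within the scatter) in this assay, shows that ethyl in place of methoxy on the aromatic carbon between the two ring nitrogen atoms does not separate the two compounds. The hydrogen-bond acceptor of methoxy can therefore be lost here, with the amide side of compound 3 held fixed, without a change beyond the scatter. Nothing available bears on the reason for this result.

On these data alone, whether the same holds with the amide side of compound 1 remains open. A propyl chain or a dimethylamino group at this position is also untested in the compounds shown.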